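Bromoacrylamide thiazolidinedione series: benzyl methyl to tert-butyl

This account rests on a few compounds, and the source may have more. Where it says the series, first, only, none or still open, it means among the compounds named here.

Measured compounds:
compound 1 `C=C(Br)C(=O)Nc1ccc(/C=C2\SC(=O)N(Cc3ccc(C)cc3)C2=O)cc1` — 3700 nM
compound 2 `Cc1ccc(CN2C(=O)S/C(=C\c3ccc(N)cc3)C2=O)cc1` — > 250000 nM

Among the measured compounds shown here, in a functional assay on CCRF-CEM cells (Homo sapiens) for cytotoxicity, read by cell counting, with a stated time of 3 days (on this read-out higher numbers stand for weaker inhibition and lower numbers for stronger inhibition), compound 1 gives 3700 nM, the only number obtained so far. For compound 2 the assay returns only a limit, > 250000 nM. For the measured compounds named here, the one measured step, an at least 67-fold higher number from compound 1 to compound 2 (1.82 log units; beyond the scatter), concerns the limit of > 250000 nM in this assay, at which 1 of the 2 values shown sits, and arises from hydrogen in place of (1-bromoethenyl)carbonyl on a nitrogen on an aromatic ring.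

Compound 3 `C=C(Br)C(=O)Nc1ccc(/C=C2\SC(=O)N(Cc3ccc(C(C)(C)C)cc3)C2=O)cc1` keeps that group and differs from compound 1 by tert-butyl in place of methyl on an aromatic carbon of a six-membered aromatic ring of carbon only. Going by the values given here, no measured step touches this part of the shared core, so the step from compound 1 to compound 2 gives no guidance here. Compound 3 is therefore expected to sit close to compound 1, with a step of no change at the digits printed from compound 1 to compound 3 (within the scatter) no larger than the usual scatter. The estimate for compound 3 is 3700 nM, within 1200 nM to 11000 nM.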

Compound 3, half-maximal inhibitory concentration: 830 nM
For compound 3 the middle estimate is 4.5-fold (0.65 log units) above the measured one, outside the stated range (below it).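

In this assay, tert-butyl in place of methyl on an aromatic carbon, para to a large group, gives a 4.5-fold lower number from compound 1 to compound 3 (0.65 log units; beyond the scatter), a modest step but one beyond the scatter. Among the compounds shown here, the earlier step concerned only the (1-bromoethenyl)carbonyl group on the nitrogen, so this is the first measured sign that a second place on the molecule also moves the number, with that group retained. Nothing measured on these compounds gives a cause for this step, and the limit seen for compound 2 concerns a different place.

With only methyl and tert-butyl at this place, the compounds shown leave open what an isopropyl group, a methoxy group or a carboxylic acid would give there. Also open, going by these compounds, is whether the same change has any effect on the free amine of compound 2.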